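A few compounds are considered here, and "the series" means these few. Any claim that something is new, unique, unknown or untested is made for them only; others in the source may bear on it.

Working notes on the propargylamine series.

Compound 1 `C#CCN(C)CCCCOc1ccc2c(c1)CCCC2=O` is the reference point. In an ADME assay on BTI cells for inhibition of Amine oxidase [flavin-containing] A (Homo sapiens), read by fluorescence and Amplex Red, with a stated time of 15 min, tested at 100 uM (on this read-out higher numbers stand for more inhibition at the one concentration tested (going by the name of the read-out) and lower numbers for less inhibition), compound 1 gives 30.9%. Compound 2 `C#CCN(C)CCCCCOc1ccc2c(c1)CCCC2=O` differs from compound 1 by one structural change, ((methyl(propargyl)amino)methyl in place of methyl(propargyl)amino on a saturated chain carbon, four bonds along the chain from an oxygen on an aromatic ring), and in this assay compound 2 gives 26.1%. The step this change made, a number 4.8 percentage points lower from compound 1 to compound 2 (within the scatter), is small and lies within the scatter of the read-out, so the two compounds are indistinguishable on this measure.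

Compound 3 `C#CCN(C)CCCOc1ccc2c(c1)OCCC2=O` carries a different core; the difference between the two cores is not broken down here. In this assay compound 3 gives 32.1%. Its values against compound 1 and compound 2 all fall within the scatter, so no ordering among the three measured compounds can be claimed.

Compound 4 `C#CCN(C)CCCCOc1ccc2c(c1)OCCC2=O` has not yet been measured in this assay. Its difference from compound 3 is (methyl(propargyl)amino)methyl in place of methyl(propargyl)amino on a saturated chain carbon, three bonds along the chain from an oxygen on an aromatic ring. This is the same kind of change as that from compound 1 to compound 2, but not the same: there the place was four bonds along the chain from an oxygen on an aromatic ring, here it is three bonds along the chain from that oxygen. Since the earlier instance of this change gave the small step of a number 4.8 percentage points lower from compound 1 to compound 2 (within the scatter), the expected step from compound 3 is of similar size, a number 4.1 percentage points lower from compound 3 to compound 4 (within the scatter), with the caveat that this rests on a single prior example on a different core. On that basis compound 4 is estimated at 28%, expected to fall between 18% and 38%.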

Compound 4, a percentage reported as inhibition, at one concentration (the size of the read-out at that concentration, not a potency): 22.8%
Compound 4: middle estimate off by 5.2 percentage points, on the high side; the measured number falls inside the stated range.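

In this assay, (methyl(propargyl)amino)methyl in place of methyl(propargyl)amino on the core of compound 3 gives a number 9.3 percentage points lower from compound 3 to compound 4 (within the scatter). Set beside the earlier instance of this change on the core of compound 1, the two steps do not separate: the same change on two cores in this assay, a number 4.8 percentage points lower (within the scatter) from compound 1 to compound 2 and a number 9.3 percentage points lower (within the scatter) from compound 3 to compound 4, 4.5 percentage points apart, within the scatter of two such steps

So far the change has been carried from one core to the other without a step beyond the scatter on either core, and without a measurable gap between the two steps; this does not show that the change has a real effect on either core, nor that it would behave alike on a further core, and two pairs read at a single concentration cannot establish a rule for the series.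

The compounds shown leave open whether a longer chain on either core, or a secondary amine or an amide in place of the methyl(propargyl)amino end, would give a step beyond the scatter in this assay. They also leave open whether the change would give comparable steps in a full concentration-response read-out, which would show the size of inhibition at more than one concentration.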